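The source may hold more compounds than are shown below. What is called first, only, known or untested is meant among the compounds shown, and "the series" means these compounds.

Compound 1 `COCCNS(=O)(=O)c1ccc(C)c(C#Cc2cc(Cl)ccc2OCC(=O)O)c1`: 33%
Compound 2 `CN(C)S(=O)(=O)c1ccc(F)c(C#Cc2cc(Cl)ccc2OCC(=O)O)c1`: 58%

In an in vivo ADME assay on the whole organism (strain BALB/c) for pharmacokinetics, with Mus musculus as the target, read by LC-MS, at a dose of 5 mg/kg by the oral route (on this read-out lower numbers stand for lower oral bioavailability and higher numbers for higher oral bioavailability), compound 1 gives 33%, the lower of the two numbers. Compound 2 gives 58%, a number that lies above compound 1 by a margin beyond the usual scatter. Compound 1 therefore stands at the bottom of the measured set.

Compound 3 `Cc1ccc(S(=O)(=O)N2CCOCC2)cc1C#Cc1cc(Cl)ccc1OCC(=O)O` has not yet been measured. It differs from compound 1 by morpholin-4-yl in place of (2-methoxyethyl)amino on a sulfonyl sulfur. Among the measured compounds shown here, no measured pair shows this particular change, so there is no directly comparable step to draw on, and the direction of the move remains open. On the two numbers available, the step is expected to be modest, a number 9 percentage points higher from compound 1 to compound 3 (within the scatter), roughly within the scatter or only slightly upward. Compound 3 is accordingly expected to give about 42%, with a range from 22% to 65%.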

Compound 3, oral bioavailability: 48%
The estimate for compound 3 lay 6 percentage points below the measured number; low and high end bracket the measured number.
By their numbers in this assay, from the lowest: compound 1; then compounds 3 and 2 (each within the scatter of the next).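

In this assay, the change at this place can now be read on its own: morpholin-4-yl in place of (2-methoxyethyl)amino on a sulfonyl sulfur gives a number 15 percentage points higher from compound 1 to compound 3 (beyond the scatter) on an otherwise unchanged structure. The oral bioavailability of this series in mice therefore responds to the group on the sulfonyl sulfur alone, which the earlier pair could not show, since compounds 1 and 2 differ in more than one place. The change swaps an open chain with one hydrogen-bond donor for a six-membered ring with none, and no measurement here explains the rise.

As far as these compounds go, whether the ring or the missing donor matters remains open; (2-methoxyethyl)(methyl)amino or piperidin-1-yl on the same sulfur would help separate the two. Also open, from the compounds shown here alone, is whether the step would hold with the fluoro group of compound 2 in place of the methyl group.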